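This account rests on a few compounds, and the source may have more. Where it says the series, first, only, none or still open, it means among the compounds named here.

Compound 1 `CN(C)C(=O)c1cc2cnc(Nc3ccc(C(=O)NCCCCCN=C=S)cc3)nc2n1C1CCCC1`: 76.5%
Compound 2 `CN(C)C(=O)c1cc2cnc(Nc3ccc(C(=O)NCCCCCCN=C=S)cc3)nc2n1C1CCCC1`: 85%
Compound 3 `CN(C)C(=O)c1cc2cnc(Nc3ccc(C(=O)NCCCN=C=S)cc3F)nc2n1C1CCCC1`: 78.5%

All three were tested in a functional assay on NCI-H1299 cells (Homo sapiens) for inhibition, read by CCK-8 assay, with a stated time of 72 h, tested at 10 uM; on this read-out higher numbers stand for a stronger effect at the one concentration tested and lower numbers for a weaker effect. Compound 1 gives 76.5%, and compound 2 gives 85%. These two share a core and differ at a single spot: a group of 4 heavy atoms (2 carbon, 1 nitrogen, 1 sulfur; no ring) in place of a group of 3 heavy atoms (1 carbon, 1 nitrogen, 1 sulfur; no ring), on a saturated chain carbon, five bonds along the chain from an amide-type nitrogen. That change gave a number 8.5 percentage points higher from compound 1 to compound 2 (within the scatter), so the two numbers cannot be told apart. Compound 3 gives 78.5%; how its core differs from the core of compound 1 is not broken down here.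

Compound 4 `CN(C)C(=O)c1cc2cnc(Nc3ccc(C(=O)NCCCCN=C=S)cc3F)nc2n1C1CCCC1` has not yet been measured. It is related to compound 3 by a group of 4 heavy atoms (2 carbon, 1 nitrogen, 1 sulfur; no ring) in place of a group of 3 heavy atoms (1 carbon, 1 nitrogen, 1 sulfur; no ring), on a saturated chain carbon, three bonds along the chain from an amide-type nitrogen. For the measured compounds named here, this is the same kind of change as the one from compound 1 to compound 2, not the same change: there the place was five bonds along the chain from an amide-type nitrogen, here it is three bonds along the chain from an amide-type nitrogen. Because the earlier step was a number 8.5 percentage points higher from compound 1 to compound 2 (within the scatter), the step expected for compound 4 is a number 3.5 percentage points higher from compound 3 to compound 4 (within the scatter). The estimate for compound 4 in this assay is 82%, expected to fall between 70% and 92%.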

Compound 4, a percentage reported as inhibition, at one concentration (the size of the read-out at that concentration, not a potency): 78.9%
Compound 4: the middle estimate sits 3.1 percentage points above what was measured; the range from low to high includes it.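

Replacing the group of 3 heavy atoms with the group of 4 heavy atoms, on a saturated chain carbon, three bonds along the chain from an amide-type nitrogen, gave a number 0.4 percentage points higher from compound 3 to compound 4 (within the scatter) in this assay. Set beside the same kind of change on the other core, the two steps cannot be told apart: the same change on two cores in this assay, a number 8.5 percentage points higher (within the scatter) from compound 1 to compound 2 and a number 0.4 percentage points higher (within the scatter) from compound 3 to compound 4, 8.1 percentage points apart, within the scatter of two such steps. For the compounds shown here, this shows only that neither core gives a step large enough to read, so it does not show that the change raises the number on either core, nor that it would act identically on both if measured more finely, and two pairs tested at a single concentration say nothing about potency.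

Every compound shown keeps the same group at the end of its chain, so what an amine or a carboxylic acid in that place would do stays open. Also open, from the compounds shown here alone, is whether a longer chain on the core of compound 3 would give a step beyond the scatter.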